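Acetyl capping of the core amine in the amide series

The source may report more compounds than this note shows. Statements on the series, on what has been measured and on what is new or still open speak of the compounds shown alone.

Compound 1 `Nc1cccc2c(-c3cccc(NC(=O)c4ccc5c(c4)OCCO5)c3)ccnc12` carries a 2,3-dihydro-1,4-benzodioxin-6-yl group on the carbonyl carbon. In a functional assay on A375P cells (Homo sapiens) for antiproliferative activity, read by MTT assay, with a stated time of 48 h (on this read-out lower numbers stand for stronger inhibition and higher numbers for weaker inhibition), compound 1 gives 860 nM, the lowest of the two numbers shown. Compound 2 `Nc1cccc2c(-c3cccc(NC(=O)c4nccs4)c3)ccnc12` gives 16700 nM, and the move is a 19-fold higher number from compound 1 to compound 2 (1.29 log units; beyond the scatter). Compound 3 `Nc1cccc2c(-c3cccc(NC(=O)c4cc5ccccc5s4)c3)ccnc12` returns only a limit, > 20000 nM, which is the limit of > 20000 nM in this assay, at which 1 of the 3 values shown sits. From compound 2 the step is an at least 1.1-fold higher number from compound 2 to compound 3 (0.07 log units; that floor lies within the scatter), and from compound 1 it is an at least 23-fold higher number from compound 1 to compound 3 (1.36 log units; beyond the scatter).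

Compound 4 `CC(=O)Nc1cccc2c(-c3cccc(NC(=O)c4ccc5c(c4)OCCO5)c3)ccnc12` differs from compound 1 by acetyl in place of hydrogen on a nitrogen on an aromatic ring. Within the data shown here, none of the measured steps touches this position: all three swap the group on the carbonyl carbon, so they bear on the change from compound 1 to compound 4 only by showing that the series can move far in this assay. Among the measured compounds shown here, with no precedent at the nitrogen, a step of no more than modest size is expected, in either direction, most likely a somewhat higher number, a 1.7-fold higher number from compound 1 to compound 4 (0.24 log units; within the scatter). Compound 4 is estimated at 1500 nM, within 300 nM to 8000 nM.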

Compound 4, half-maximal inhibitory concentration: 570 nM
The estimate for compound 4 lay 2.6-fold (0.42 log units) above the measured number, and the stated range covers the measured number.
By their numbers in this assay, from the lowest: compounds 4 and 1 (each within the scatter of the next); then compound 2. At a limit, above all of these: compound 3.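

Acetyl in place of hydrogen on a nitrogen on an aromatic ring gives a 1.5-fold lower number from compound 1 to compound 4 (0.18 log units; within the scatter) in this assay, so in this pair the amino group can be capped as acetamido without a step beyond the scatter. This position therefore differs from the group on the carbonyl carbon, where a single swap gives a 19-fold higher number from compound 1 to compound 2 (1.29 log units; beyond the scatter). The information at hand offers no explanation for how little the number moves at this nitrogen.

On these data alone, this rests on one pair with the 2,3-dihydro-1,4-benzodioxin-6-yl amide, so it remains open whether acetyl is tolerated in the same way with the 1,3-thiazol-2-yl amide of compound 2. Also open, as far as these compounds go, is how a longer acyl chain such as propanoyl, a benzoyl group or a simple methyl group on the same nitrogen would compare.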